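A few compounds are considered here, and "the series" means these few. Any claim that something is new, unique, unknown or untested is made for them only; others in the source may bear on it.

Measured compounds:
compound 1, `CCN(CC)CCCC(C)Nc1ccnc(COc2ccccc2)n1`, in an assay on isolated protein for inhibition of C-C chemokine receptor type 4 (Homo sapiens); on this read-out lower numbers stand for stronger inhibition and higher numbers for weaker inhibition: > 30000 nM, which is a limit of the assay and not a number.
compound 2, `CCN(CC)CCCNc1nccc(OCc2ccc(Cl)cc2Cl)n1`, in this assay: 8000 nM.
compound 3, `CCN(CC)CCCCNc1nccc(OCc2ccc(Cl)cc2Cl)n1`, in this assay: 3000 nM.

Compound 3 stands at the lowest of the two numbers in the set. Its nearest neighbour is compound 2, and the step of a 2.7-fold lower number from compound 2 to compound 3 (0.43 log units; beyond the scatter) is modest but beyond the scatter. Compound 1 sits at the limit of > 30000 nM in this assay, at which 1 of the 3 values shown sits, and contributes no number for comparison.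

Compound 4, `CCN(CC)CCNc1nccc(OCc2ccc(Cl)cc2Cl)n1`, is yet to be measured in this assay. It differs from compound 3 in one place: diethylamino in place of 2-(diethylamino)ethyl on a saturated chain carbon, two bonds along the chain from a nitrogen on an aromatic ring. Within the data shown here, this is the same kind of change as the one measured step, but run the other way and further: where a 2.7-fold lower number from compound 2 to compound 3 (0.43 log units; beyond the scatter) came with a longer chain, compound 4 carries a shorter chain than either compound 2 or compound 3. Among the measured compounds shown here, only that one step bears on the question, and it was modest. A weaker number is therefore expected for compound 4, with the step of a 5.0-fold higher number from compound 3 to compound 4 (0.70 log units; beyond the scatter) taken as the estimate. Compound 4 is expected to give about 15000 nM, within the range 5000 nM to 60000 nM, with a fair chance that only a limit is returned.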

Compound 4, half-maximal inhibitory concentration: 9000 nM
Beside the measured number, compound 4's estimate is 1.7-fold (0.22 log units) above it; the range from low to high includes it.
By their numbers in this assay, from the lowest: compound 3; then compounds 2 and 4 (each within the scatter of the next). At a limit, above all of these: compound 1.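

Compound 3 now stands apart from both shorter-chain compounds: alongside the earlier 2.7-fold lower number from compound 2 to compound 3 (0.43 log units; beyond the scatter) comes a 3.0-fold higher number from compound 3 to compound 4 (0.48 log units; beyond the scatter), so in this assay the lower number goes with the 2-(diethylamino)ethyl group at this place, on a saturated chain carbon, two bonds along the chain from a nitrogen on an aromatic ring. The two shorter chains cannot be told apart, since a 1.1-fold higher number from compound 2 to compound 4 (0.05 log units; within the scatter) gives no steady response to chain length across these three compounds, only a separation of compound 3 from compounds 2 and 4. Nothing at hand accounts for this difference between the chains.

The compounds shown leave open whether a longer chain than that of compound 3 would bring the number lower still or whether the series turns back at that length. They also leave open whether a cyclic amine such as piperidine, in place of the diethylamino group on the chain of compound 3, would hold the number of compound 3.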